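Amide variations on a cyanoindoline sulfonamide: Caco-2 permeability notes

A few compounds are considered here, and "the series" means these few. Any claim that something is new, unique, unknown or untested is made for them only; others in the source may bear on it.

Measured compounds:
- compound 1, `Cn1cncc1CN1CC(N(CC2CCN(C(=O)C(C)(C)C)CC2)S(=O)(=O)c2ccccn2)Cc2cc(C#N)ccc21`: 0.5 10^-6 cm/s
- compound 2, `Cn1cncc1CN1CC(N(CC2CCN(C(=O)CC(C)(C)C)CC2)S(=O)(=O)c2ccccn2)Cc2cc(C#N)ccc21`: 0.5 10^-6 cm/s
- compound 3, `Cn1cncc1CN1CC(N(CC2CCN(C(=O)c3cccs3)CC2)S(=O)(=O)c2ccccn2)Cc2cc(C#N)ccc21`: 0.5 10^-6 cm/s

In an ADME assay on Caco-2 cells (Homo sapiens) for permeability, in the apical to basolateral direction (a lower number here means that the compound crosses the layer more slowly, a higher number that the compound crosses the layer faster), compound 2 gives 0.5 10^-6 cm/s, level with compound 1 and compound 3 at the digits printed. The steps between the measured compounds, no change at the digits printed from compound 1 to compound 2 (within the scatter), no change at the digits printed from compound 1 to compound 3 (within the scatter) and no change at the digits printed from compound 2 to compound 3 (within the scatter), all stay within the scatter: swapping tert-butyl, neopentyl and thiophen-2-yl on the carbonyl carbon leaves the read-out where it is.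

Compound 4, `CCNC(=O)N1CCC(CN(C2Cc3cc(C#N)ccc3N(Cc3cncn3C)C2)S(=O)(=O)c2ccccn2)CC1`, remains to be measured. It differs from compound 2 as follows: ethylamino in place of neopentyl on a carbonyl carbon. None of the three measured steps brings in a hydrogen-bond donor, so they bear on this change only by showing that the carbonyl substituent has so far not moved the read-out. For the measured compounds named here, with no closer precedent, a step of no more than modest size is expected, a 1.3-fold lower number from compound 2 to compound 4 (0.10 log units; within the scatter), if anything toward the lower side. The expected value for compound 4 is 0.4 10^-6 cm/s, within the range 0.15 10^-6 cm/s to 1.2 10^-6 cm/s.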

Compound 4, apparent permeability: 0.6 10^-6 cm/s
Beside the measured number, compound 4's estimate is 1.5-fold (0.18 log units) below it, within the range that was stated.
By their numbers in this assay, from the lowest: compounds 1, 2, 3 and 4 (each within the scatter of the next).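

For the compounds shown here, compound 4 is the first of the series to place a hydrogen-bond donor on this carbonyl carbon, yet in this assay the read-out holds: a 1.2-fold higher number from compound 2 to compound 4 (0.08 log units; within the scatter) and a 1.2-fold higher number from compound 3 to compound 4 (0.08 log units; within the scatter) and also a 1.2-fold higher number from compound 1 to compound 4 (0.08 log units; within the scatter). At this position, then, ethylamino cannot be told apart from neopentyl, tert-butyl or thiophen-2-yl, and the neopentylcarbonyl to ethylcarbamoyl change adds the amide hydrogen without shifting the number beyond the scatter. No available data explain why the read-out stays level.

Still open, as far as these compounds go, is whether a carbonyl substituent ending in a tertiary amine or a carboxylic acid would leave this level. All four compounds differ only at this carbonyl carbon, which leaves the response to replacing the nitrile on the shared core, for example with a primary amide, untested here.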